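Trimethoxyphenyl versus dimethoxyphenyl: the next step in the series

The compounds below may be only part of what the source reports. "The series", "measured", "known", "first", "only" and "open" are said of these compounds alone.

Measured in a functional assay on A549 cells (Homo sapiens) for cytotoxicity, read by MTT assay, with a stated time of 72 h; a higher number here means a weaker inhibitor, a lower number a stronger inhibitor:
- compound 1 `COc1ccc(/C=C/C(=O)Nc2cc3c(Nc4ccc(F)c(Cl)c4)ncnc3cc2O[C@H]2CCOC2)c(OC)c1`: 9350 nM
- compound 2 `COc1ccc(OC)c(/C=C/C(=O)Nc2cc3c(Nc4ccc(F)c(Cl)c4)ncnc3cc2O[C@H]2CCOC2)c1`: 7300 nM
- compound 3 `COc1ccc(/C=C/C(=O)Nc2cc3c(Nc4ccc(F)c(Cl)c4)ncnc3cc2O[C@H]2CCOC2)c(OC)c1OC`: 70 nM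

Compound 3 gives the lowest of the three numbers, at 70 nM. Compound 4 `COc1cc(/C=C/C(=O)Nc2cc3c(Nc4ccc(F)c(Cl)c4)ncnc3cc2O[C@H]2CCOC2)cc(OC)c1` has not yet been measured. It differs from compound 3 as follows: 3,5-dimethoxyphenyl in place of 2,3,4-trimethoxyphenyl on a double-bonded chain carbon bound to a double-bonded chain carbon, with 3,5-dimethoxyphenyl in place of 2,3,4-trimethoxyphenyl on a double-bonded chain carbon bound to a double-bonded chain carbon.

Among the measured compounds shown here, three measured steps bear on this change. The two dimethoxyphenyl compounds show a 1.3-fold lower number from compound 1 to compound 2 (0.11 log units; within the scatter), so swapping one dimethoxyphenyl group for another made no clear difference there. Both large steps come with the trimethoxyphenyl group: a 130-fold lower number from compound 1 to compound 3 (2.13 log units; beyond the scatter) and a 100-fold lower number from compound 2 to compound 3 (2.02 log units; beyond the scatter). On these data alone, compound 4 returns to a dimethoxyphenyl group, so a large step to a higher number is expected in this assay, although this exact group remains untested. The expected step is a 71-fold higher number from compound 3 to compound 4 (1.85 log units; beyond the scatter). For compound 4 the estimate is 5000 nM, with an expected range of 800 nM to 15000 nM.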

Compound 4, half-maximal inhibitory concentration: 10800 nM
The estimate for compound 4 lay 2.2-fold (0.33 log units) below the measured number; measured number inside the range.
By their numbers in this assay, from the lowest: compound 3; then compounds 2, 1 and 4 (each within the scatter of the next).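

Both a 1.5-fold higher number from compound 2 to compound 4 (0.17 log units; within the scatter) and a 1.2-fold higher number from compound 1 to compound 4 (0.06 log units; within the scatter) place the 3,5-dimethoxyphenyl group with the other two dimethoxyphenyl groups in this assay, so three different dimethoxyphenyl groups on this double-bonded chain carbon now give numbers within the scatter of each other. The large step seen in a 150-fold higher number from compound 3 to compound 4 (2.19 log units; beyond the scatter) is therefore not tied to one particular dimethoxyphenyl group. Among these four compounds, the low number belongs to the 2,3,4-trimethoxyphenyl group alone, and no compound shown goes against this.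

On these data alone, it remains open whether any third methoxy group gives the low number or only this arrangement does; a 3,4,5-trimethoxyphenyl group, or a 2,3,4-trimethoxyphenyl group with one methoxy replaced by hydroxyl or an amine, would separate the two readings. Nothing shown gives a reason for the gap between compound 3 and the other three compounds.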